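The source may report more compounds than this note shows. Statements on the series, on what has been measured and on what is new or still open speak of the compounds shown alone.

Going by the values given here, compound 2, `Cc1ccccc1Cc1ccc(N2C[C@@H](C(F)(F)F)C[C@H]2CC(=O)O)cc1`, gives 73 nM in an assay on HEK293 cells for binding affinity to Free fatty acid receptor 1 (Homo sapiens), read by scintillation counting and radioligand binding, with a stated time of 1 h (on this read-out lower numbers stand for stronger inhibition and higher numbers for weaker inhibition), the lower of the two numbers measured so far, while compound 1, `Cc1ccccc1Cc1ccc(N2C[C@@H](C)C[C@H]2CC(=O)O)cc1`, gives 360 nM. Among the compounds with values here, the only measured step, a 4.9-fold lower number from compound 1 to compound 2 (0.69 log units; beyond the scatter), concerns a group on a saturated ring carbon. Compound 3, `COc1ccc(F)c(-c2ccc(Cc3ccc(N4C[C@@H](C(F)(F)F)C[C@H]4CC(=O)O)cc3)c(C)c2)c1`, differs from compound 2 by 2-fluoro-5-methoxyphenyl in place of hydrogen on an aromatic carbon. Within the data shown here, no measured step touches that aromatic position, so the direction of the change is uncertain. A modest improvement is nonetheless expected, giving a 1.8-fold lower number from compound 2 to compound 3 (0.26 log units; within the scatter), with compound 3 estimated at 40 nM, within a range from 8 nM to 200 nM.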

Compound 3, inhibition constant: 45 nM
Estimate against measurement, compound 3: 1.1-fold (0.05 log units) below; measured number inside the range.
By their numbers in this assay, from the lowest: compounds 3 and 2 (each within the scatter of the next); then compound 1.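

Putting 2-fluoro-5-methoxyphenyl on this aromatic carbon gives a 1.6-fold lower number from compound 2 to compound 3 (0.21 log units; within the scatter) in this assay. The position therefore accepts a group of 9 heavy atoms, with one more aromatic ring, while the number stays level with that of the smaller compound. No supporting data offer a reason for this result.

From the compounds shown here alone, it remains open whether the fluorine or the methoxy matters at all, since a plain phenyl could be compared directly. A ring carrying an amine or a carboxylic acid at this position is also an open case.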